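This account rests on a few compounds, and the source may have more. Where it says the series, first, only, none or still open, it means among the compounds named here.

Among the measured compounds shown here, compound 2 `COc1ccccc1-c1nnc(-c2ccc(C(=O)N/N=C/c3cccc([N+](=O)[O-])c3)cc2)o1` stands lowest of the three numbers so far in an ADME assay on THP-1 cells (Homo sapiens) for cytotoxicity (on this read-out lower numbers stand for stronger inhibition and higher numbers for weaker inhibition), where compound 2 gives 119000 nM. Its nearest neighbour is compound 3 `COc1ccccc1-c1nnc(-c2ccc(C(=O)N/N=C/c3ccccc3F)cc2)o1`, which in this assay gives 313000 nM; the furthest is compound 1 `COc1ccccc1-c1nnc(-c2ccc(C(=O)N/N=C/c3cccc(O)c3)cc2)o1`, which gives 398000 nM. Compound 4 `COc1ccccc1-c1nnc(-c2ccc(C(=O)N/N=C/c3ccccn3)cc2)o1` has not been measured yet. It differs from compound 2 in one place: pyridin-2-yl in place of 3-nitrophenyl on a carbon with a double bond to nitrogen.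

For the measured compounds named here, two measured steps bear on this change, both of them touching the same aromatic ring on the carbon with a double bond to nitrogen. There was a 3.3-fold lower number from compound 1 to compound 2 (0.52 log units; beyond the scatter), and there was a 2.6-fold higher number from compound 2 to compound 3 (0.42 log units; beyond the scatter). In both, the compound carrying the 3-nitrophenyl group gave the lower number, and the step in either direction was modest but beyond the scatter. Compound 4 loses the 3-nitrophenyl group and gains a pyridin-2-yl group, so a modest rise in the number is expected, of about the size seen when compound 2 went to compound 3, which would mean a 2.5-fold higher number from compound 2 to compound 4 (0.40 log units; beyond the scatter). Compound 4 is therefore estimated to give 300000 nM in this assay, with a likely range from 120000 nM to 750000 nM.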

Compound 4, half-maximal inhibitory concentration: 67000 nM
Beside the measured number, compound 4's estimate is 4.5-fold (0.65 log units) above it; the measured number lies below the stated range.
By their numbers in this assay, from the lowest: compounds 4 and 2 (each within the scatter of the next); then compounds 3 and 1 (each within the scatter of the next).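

In this assay, among the compounds shown here, the earlier compounds left the 3-nitrophenyl group alone at the low end, but the step to pyridin-2-yl, a 1.8-fold lower number from compound 2 to compound 4 (0.25 log units; within the scatter), shows that a ring without a nitro group on the carbon with a double bond to nitrogen can sit level with it. The pyridin-2-yl group also stands clear of the other two rings, with a 4.7-fold lower number from compound 3 to compound 4 (0.67 log units; beyond the scatter) and a 5.9-fold lower number from compound 1 to compound 4 (0.77 log units; beyond the scatter), so the four compounds now form two pairs, compound 4 with compound 2 and compound 3 with compound 1. Nothing available here accounts for why these rings divide in this way.

The compounds shown leave open whether the place of the ring nitrogen matters, as pyridin-3-yl and pyridin-4-yl do not appear among them. They also leave open how this position responds to a ring carrying an amine or a carboxylic acid, or to a saturated ring such as piperidine in place of the aromatic one.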